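Compound 4 against the limit of compound 2

The source may report more compounds than this note shows. Statements on the series, on what has been measured and on what is new or still open speak of the compounds shown alone.

Values so far in a functional assay on NCI-H460 cells (Homo sapiens) for inhibition, read by MTT assay, with a stated time of 4 days (a lower number here means a stronger inhibitor, a higher number a weaker inhibitor), are these
- compound 1 `COc1cc(NC(C)CCCNC(=O)NNC(=O)Nc2ccc(Cl)c(C(F)(F)F)c2)c2ncccc2c1` gives 13000 nM
- compound 2 `COc1cc(NC(C)CCCNC(=O)NNC(=O)NCCO)c2ncccc2c1` gives > 100000 nM as a limit
- compound 3 `O=C(NC(c1ccccc1)c1ccc(Cl)cc1)NC(c1ccccc1)c1ccc(Cl)cc1` gives > 100000 nM as a limit

Compound 2 has only a limit to show and no number, with the limit of > 100000 nM in this assay, at which 2 of the 3 values shown sit, as its standing. Compound 4 `COc1cc(NC(C)CCCNC(=O)Nc2ccc(Cl)c(C(F)(F)F)c2)c2ncccc2c1` carries 4-chloro-3-(trifluoromethyl)phenyl in place of ((2-hydroxyethyl)carbamoyl)amino on an amide-type nitrogen and keeps the rest. Among the measured compounds shown here, the one measured step that bears on this is an at least 7.6-fold higher number from compound 1 to compound 2 (0.88 log units; beyond the scatter) (itself bounded by a limit) and it marks the loss of that same group. A step toward a lower number is therefore expected in this assay and is estimated as an at least 10-fold lower number from compound 2 to compound 4 (1.00 log units; beyond the scatter) for this change. For compound 4 the expected value is 10000 nM with 2500 nM to 40000 nM as the estimated range.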

Compound 4, half-maximal inhibitory concentration: 28000 nM
Beside the measured number, compound 4's estimate is 2.8-fold (0.45 log units) below it; the measured number falls inside the stated range.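

In this assay, 4-chloro-3-(trifluoromethyl)phenyl placed directly on the amide-type nitrogen also gives a measurable number, with an at least 3.5-fold lower number from compound 2 to compound 4 (0.55 log units; beyond the scatter). The earlier step, an at least 7.6-fold higher number from compound 1 to compound 2 (0.88 log units; beyond the scatter), showed this group only with the longer carbamoylamino link retained, so the link is not required for a measurable number. The size of the new step remains open-ended, as compound 2 has only a limit: the limit of > 100000 nM in this assay, at which 2 of the 4 values shown sit.

On these data alone, whether an unsubstituted phenyl, a primary amine or a carboxylic acid at this place would also give a measurable number remains open. As far as these compounds go, the separate contributions of the chloro and trifluoromethyl groups also remain open.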